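The source may report more compounds than this note shows. Statements on the series, on what has been measured and on what is new or still open speak of the compounds shown alone.

In a functional assay on MCF7 cells (Homo sapiens) for inhibition, read by MTT assay, with a stated time of 3 days (on this read-out lower numbers stand for stronger inhibition and higher numbers for weaker inhibition), compound 1 (`Cc1ccc(/C=N/NC(=O)COc2ccc3c(C)cc(=O)oc3c2)o1`) gives 3190 nM, while compound 2 (`O=c1oc2ccc(S(=O)(=O)N3CCOCC3)cc2cc1Br`) gives 13200 nM. This is the higher of the two numbers, marking compound 2 as the weaker inhibitor by a gap beyond the scatter. Compound 3 (`CN1CCN(S(=O)(=O)c2ccc3oc(=O)c(Br)cc3c2)CC1`) keeps the core of compound 2 and carries 4-methylpiperazin-1-yl in place of morpholin-4-yl on a sulfonyl sulfur. Among the compounds with values here, no measured pair shows this change, so the expectation is loose: no shift beyond the scatter in this assay. The estimated step is a 1.5-fold lower number from compound 2 to compound 3 (0.17 log units; within the scatter). For compound 3 the expected value is 9000 nM, with an estimated range of 3500 nM to 25000 nM.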

Compound 3, half-maximal inhibitory concentration: 31400 nM
The estimate for compound 3 lay 3.5-fold (0.54 log units) below the measured number; the measured number lies above the stated range.
By their numbers in this assay, from the lowest: compound 1; then compound 2; then compound 3.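

On the sulfonyl sulfur, 4-methylpiperazin-1-yl in place of morpholin-4-yl is not a neutral exchange in this assay: it gives a 2.4-fold higher number from compound 2 to compound 3 (0.38 log units; beyond the scatter), a modest step towards weaker inhibition. Within the data shown here, this is the first sign that the number at this position responds to the group carried there, which the unrelated compound 1 and compound 2 could not show. Nothing available explains the shift.

As far as these compounds go, it remains open whether piperazin-1-yl without the methyl, or piperidin-1-yl, would read nearer compound 2 or compound 3. From the compounds shown here alone, a dimethylamino group, with no ring at all, is equally open.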